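The source may hold more compounds than are shown below. What is called first, only, known or untested is meant among the compounds shown, and "the series" means these compounds.

Compound 1 `CCOC(=O)c1cc([Se]Cc2ccccc2)c2cc(OC)ccc2n1`: 20800 nM
Compound 2 `CCOC(=O)c1cc([Se]c2ccccc2)c2cc(Cl)ccc2n1`: 53000 nM

In a functional assay on Jurkat cells (Homo sapiens) for cytotoxicity, read by MTT assay, with a stated time of 24 h (a lower number here means that less compound is needed, a higher number that more compound is needed for the effect), compound 2 has the higher number of the two at 53000 nM, and the gap to compound 1 lies beyond the scatter. Compound 3 `CCOC(=O)c1cc([Se]Cc2ccccc2)c2cc(Cl)ccc2n1` differs from compound 2 in one place: benzyl in place of phenyl on a selenium. Among the measured compounds shown here, no measured pair isolates this change. Compound 1 also carries benzyl on selenium and gives 20800 nM, but it differs from compound 2 elsewhere as well, so only a modest fall in the number is expected, close to the edge of the scatter. The expected change is a 1.9-fold lower number from compound 2 to compound 3 (0.28 log units; within the scatter). For compound 3 the estimate is 28000 nM, with an expected range of 12000 nM to 60000 nM.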

Compound 3, half-maximal effective concentration: 88500 nM
Compound 3: the middle estimate sits 3.2-fold (0.50 log units) below what was measured, and the stated range ends below it.
By their numbers in this assay, from the lowest: compound 1; then compounds 2 and 3 (each within the scatter of the next).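

Benzyl in place of phenyl on a selenium does not separate the two compounds in this assay (a 1.7-fold higher number from compound 2 to compound 3 (0.22 log units; within the scatter)), so this change at the selenium has no readable effect with chloro on the core. With benzyl held on selenium, chloro in place of methoxy on an aromatic carbon gives a step beyond the scatter (a 4.3-fold higher number from compound 1 to compound 3 (0.63 log units; beyond the scatter)), which shows that this aromatic carbon matters in this pair. Nothing available bears on the reason for either step.

Still open, on these data alone, is how an amine or a carboxylic acid on that aromatic carbon would read. As far as these compounds go, a longer chain on selenium is equally open.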